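Aryl amide variation on a shared quinazoline-free core series

A few compounds are considered here, and "the series" means these few. Any claim that something is new, unique, unknown or untested is made for them only; others in the source may bear on it.

Measured so far:
- Compound 1, `O=C(CSc1nc(Nc2ccccc2)c2ccccc2n1)Nc1cccc([N+](=O)[O-])c1`: 11800 nM in a functional assay on PC-3 cells (Homo sapiens) for inhibition, read by MTT assay, with a stated time of 72 h; on this read-out higher numbers stand for weaker inhibition and lower numbers for stronger inhibition
- Compound 2, `O=C(CSc1nc(Nc2ccccc2)c2ccccc2n1)Nc1ccc(Br)cc1`: 8450 nM in this assay

Within the data shown here, compound 2 stands within the scatter of compound 1; the one measured step, a 1.4-fold lower number from compound 1 to compound 2 (0.15 log units; within the scatter), is the only comparison bearing on the aryl amide, and it shows no real shift. Compound 3, `O=C(CSc1nc(Nc2ccccc2)c2ccccc2n1)Nc1ccc(Cl)cc1Cl`, differs from compound 2 by 2,4-dichlorophenyl in place of 4-bromophenyl on an amide-type nitrogen. With a single aryl-amide step that stayed within the scatter, the expectation for compound 3 is a 1.1-fold lower number from compound 2 to compound 3 (0.05 log units; within the scatter), no shift beyond the scatter. Compound 3 is therefore estimated at 7500 nM, expected range 2500 nM to 22000 nM.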

Compound 3, half-maximal inhibitory concentration: 9110 nM
The estimate for compound 3 lay 1.2-fold (0.08 log units) below the measured number, and the stated range covers the measured number.
By their numbers in this assay, from the lowest: compounds 2, 3 and 1 (each within the scatter of the next).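

At the amide-type nitrogen, 2,4-dichlorophenyl in place of 4-bromophenyl gives a 1.1-fold higher number from compound 2 to compound 3 (0.03 log units; within the scatter) and 2,4-dichlorophenyl in place of 3-nitrophenyl gives a 1.3-fold lower number from compound 1 to compound 3 (0.11 log units; within the scatter) in this series. All three aryl groups therefore stand within the scatter of one another in this assay, and this holds for the ring carrying two chlorine atoms as well. No supporting evidence bears on this result.

Still open, on these data alone, is whether an aryl ring carrying an amine or a carboxylic acid would move the number beyond the scatter. As far as these compounds go, a longer alkyl chain in place of the aryl ring remains equally open.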